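Oxamate ester series: alkyl ester variation and paw edema

The source may hold more compounds than are shown below. What is called first, only, known or untested is meant among the compounds shown, and "the series" means these compounds.

The series rests on one shared core, seen in compound 1 `CCOC(=O)C(=O)Nc1cccccc1=O` and compound 2 `CC(C)OC(=O)C(=O)Nc1cccccc1=O`, which differ only in the ester alkyl group. In a functional assay on the whole organism (strain Sprague-Dawley CD) for inhibition, with Rattus norvegicus as the target, read by paw edema, at a dose of 10 mg/kg by the intraperitoneal route (on this read-out lower numbers stand for a weaker effect and higher numbers for a stronger effect at the one dose given), compound 1 gives 80%, and compound 2 gives 76%. For the measured compounds named here, the one step measured so far, a number 4 percentage points lower from compound 1 to compound 2 (within the scatter), shows that replacing the ethyl ester by an isopropyl ester left the read-out essentially unchanged. On the two numbers available, compound 2 stands at the lower of the pair, but its gap to compound 1 is within the scatter, so no order between the two can be claimed.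

Compound 3 `CCCCCOC(=O)C(=O)Nc1cccccc1=O` is the next member awaiting measurement. It differs from compound 2 in the same place, the ester alkyl: pentyl in place of isopropyl on an oxygen next to a carbonyl group. Going by the values given here, the only step that bears on it is a number 4 percentage points lower from compound 1 to compound 2 (within the scatter), a change of the same kind at the same position that produced no movement beyond the scatter. Absent any other measured ester variation, no step beyond the scatter is expected in this assay for this change either, though the one prior step leaned slightly downward. For compound 3 the estimated step is a number 4 percentage points lower from compound 2 to compound 3 (within the scatter), a number that is expected to sit close to compound 2. Compound 3 is therefore estimated at 72%, with a plausible range from 55% to 88%.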

Compound 3, a percentage reported as inhibition, in the whole organism at one dose (the size of the read-out at that dose, not a potency): 61%
Compound 3: the middle estimate sits 11 percentage points above what was measured; the range from low to high includes it.
By their numbers in this assay, from the lowest: compound 3; then compounds 2 and 1 (each within the scatter of the next).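

For the compounds shown here, the ester alkyl position is not indifferent in this assay: pentyl in place of isopropyl on an oxygen next to a carbonyl group gives a number 15 percentage points lower from compound 2 to compound 3 (beyond the scatter) and, set against the ethyl ester, the pentyl ester gives a number 19 percentage points lower from compound 1 to compound 3 (beyond the scatter); these are the only steps that lie beyond the scatter. Compound 3 therefore stands lowest of the three, whereas the ethyl and isopropyl esters, within the scatter of each other, show no order, so the loss of read-out at the one dose goes with the pentyl ester and not with every change of the ester alkyl. Nothing available explains why the pentyl ester reads lower.

With only three alkyl esters shown, it remains open whether the read-out keeps falling with a longer chain such as octyl, or whether a shorter methyl ester would stay level with the ethyl and isopropyl esters. Also open, as far as these compounds go, is how a benzyl ester, or the free carboxylic acid in place of the ester, would read at this position.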